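This account rests on a few compounds, and the source may have more. Where it says the series, first, only, none or still open, it means among the compounds named here.

Working notes on a series of acylated cytosine nucleosides read in a functional assay on HCT-116 cells (Homo sapiens) for cytotoxicity, read by sulforhodamine B assay, with a stated time of 24 h; a higher number here means a weaker inhibitor, a lower number a stronger inhibitor. Compound 1 `CC(C)CCC(=O)Nc1ccn([C@H]2CC[C@H](O)[C@@H](C)O2)c(=O)n1` carries an isopentylcarbonyl amide on the shared core. In this assay compound 1 gives > 20000 nM, which is a limit of the assay and not a measured number. Compound 2 `CC(C)=CC(=O)Nc1ccn([C@H]2C[C@@H](O)[C@H](O)[C@@H](C)O2)c(=O)n1` likewise reaches only a limit in this assay, > 20000 nM. Going by the values given here, compound 3 `C/C=C(\C)C(=O)Nc1ccn([C@H]2CC[C@H](O[C@H]3O[C@H](C)[C@@H](N(C)C)[C@H](O)[C@H]3O)[C@@H](C)O2)c(=O)n1`, bearing a dimethylamino sugar, gives 6450 nM in this assay and is the single compound with a number. From the compounds shown here alone, compound 1 thus stands at the limit of > 20000 nM in this assay, at which 2 of the 3 values shown sit, so its true potency is unknown beyond that bound.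

Compound 4 `C[C@H]1O[C@@H](n2ccc(NC(=O)CC(C)(C)O)nc2=O)CC[C@@H]1O` is not yet measured. It differs from compound 1 by 1-hydroxy-1-methylethyl in place of isobutyl on a saturated chain carbon bound to a carbonyl carbon. Among the compounds with values here, no measured pair in the set isolates this change, so the expectation rests only on where compound 1 sits. The step is expected to be a step that the limit leaves unreadable from compound 1 to compound 4, that is none beyond the scatter, and most probably the assay again reports a limit. For compound 4 the estimate in this assay is 25000 nM, with a range from 8000 nM to 70000 nM.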

Compound 4, half-maximal inhibitory concentration: > 20000 nM
Compound 4 ended at the assay's limit; the forecaster's own chance of this, stated with the estimate: 80%; the middle value does not contradict the limit.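

Compound 1 and compound 4 both end at a limit of the assay, so no step between them can be read: the limit of > 20000 nM in this assay, at which 3 of the 4 values shown sit.

The compounds shown leave open whether 1-hydroxy-1-methylethyl in place of isobutyl on a saturated chain carbon bound to a carbonyl carbon changes cytotoxicity at all.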